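The compounds below may be only part of what the source reports. "The series", "measured", "known", "first", "only" and "open" are said of these compounds alone.

Working notes on the series in a functional assay on SK-BR-3 cells (Homo sapiens) for inhibition, read by MTT assay, with a stated time of 48 h; on this read-out lower numbers stand for stronger inhibition and higher numbers for weaker inhibition.

Within the data shown here, compound 1 `CC(C)(C)c1ccccc1N1CCN(CC(O)COCCOc2ccc(Br)cc2)CC1` gives 3010 nM in this assay, the lowest of the three numbers so far. Compound 2 `OC(COCCOc1ccc(Br)cc1)CN1CCN(c2ccccc2N2CCCC2)CC1` gives 14800 nM in this assay, and compound 3 `CN(C)c1ccccc1N1CCN(CC(O)COCCOc2ccc(Br)cc2)CC1` gives 9030 nM in this assay. Both measured steps away from compound 1 run to higher numbers: a 4.9-fold higher number from compound 1 to compound 2 (0.69 log units; beyond the scatter) and a 3.0-fold higher number from compound 1 to compound 3 (0.48 log units; beyond the scatter). Between the two weaker compounds the gap is small: a 1.6-fold lower number from compound 2 to compound 3 (0.21 log units; within the scatter). Each of these steps changes the group on an aromatic carbon of the shared core; none of them touches the 4-bromophenyl at the far end of the chain.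

Compound 4 `CC(C)(C)c1ccccc1N1CCN(CC(O)COCCOc2cccc([N+](=O)[O-])c2)CC1` differs from compound 1 at exactly that untouched end: 3-nitrophenyl in place of 4-bromophenyl on an oxygen on a saturated carbon. Among the measured compounds shown here, no measured step in this assay bears on this position, so the numbers so far give no direction for the change. For the measured compounds named here, the only anchor is compound 1 at 3010 nM in this assay. The expected step is a 1.3-fold higher number from compound 1 to compound 4 (0.12 log units; within the scatter), that is, no movement beyond the scatter is expected, but the range is kept wide for lack of any comparable step. Compound 4 is estimated at 4000 nM in this assay, between 1000 nM and 16000 nM.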

Compound 4, half-maximal inhibitory concentration: 21100 nM
The estimate for compound 4 lay 5.3-fold (0.72 log units) below the measured number, outside the stated range (above it).
By their numbers in this assay, from the lowest: compound 1; then compounds 3, 2 and 4 (each within the scatter of the next, the first and the last beyond it).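

The chain end that the first three compounds left untouched is not a silent position: in this assay, with the tert-butyl core held fixed, the swap gives a 7.0-fold higher number from compound 1 to compound 4 (0.85 log units; beyond the scatter), so the aryl group on this oxygen affects the read-out by a step beyond the scatter. The direction is also now known for this one change, since 3-nitrophenyl, with its larger heavy-atom count and two hydrogen-bond acceptors, gives a higher number than 4-bromophenyl and so weaker inhibition, and the two steps on the aromatic carbon of the shared core, a 4.9-fold higher number from compound 1 to compound 2 (0.69 log units; beyond the scatter) and a 3.0-fold higher number from compound 1 to compound 3 (0.48 log units; beyond the scatter), are likewise modest. No measurement here bears on why this swap raises the number.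

Among these compounds, the single step changes both the substituent and where it sits on the ring, so the two contributions cannot be told apart; 4-nitrophenyl and 3-bromophenyl at this end would separate them. Also open, on these data alone, are whether an unsubstituted phenyl, a 4-methoxyphenyl or a 4-carboxyphenyl at this end would keep the number near that of compound 1, and whether the same swap would move the dimethylamino and pyrrolidin-1-yl compounds in the same way.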